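Replacing One Five-Membered Ring in Compound 1

The source may report more compounds than this note shows. Statements on the series, on what has been measured and on what is new or still open speak of the compounds shown alone.

Compound 1 `CCN(Cc1cccs1)C(=O)COc1ccc(C)cc1` is the reference point here. For the measured compounds named here, in an assay on HEK293 cells for agonist activity at transient receptor potential cation channel subfamily M member 8 (Homo sapiens), read by fluorescence and calcium flux, with a stated time of 15 min (on this read-out lower numbers stand for an effect already at smaller amounts and higher numbers for an effect only at larger amounts of compound), compound 1 gives 8 nM, the lowest of the three numbers measured so far. Compound 3 `CON(Cc1cccs1)C(=O)COc1ccc(C)cc1` gives 10 nM in this assay, and a 1.3-fold higher number from compound 1 to compound 3 (0.10 log units; within the scatter). Compound 2 `CCc1ccc(OCC(=O)N(CC)Cc2cccs2)cc1` gives 67 nM, and an 8.4-fold higher number from compound 1 to compound 2 (0.92 log units; beyond the scatter).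

Compound 4 `CCN(Cc1cc[nH]c1)C(=O)COc1ccc(C)cc1` has not yet been measured. It differs from compound 1 in one place: 1H-pyrrol-3-yl in place of thiophen-2-yl on a saturated chain carbon bound to an amide-type nitrogen. Neither measured step touches this part of the molecule. The step from compound 1 to compound 2 alters the group on the aromatic ring at the other end of the molecule, and the step from compound 1 to compound 3 alters the group on the amide-type nitrogen; the ring that leaves in compound 4 was kept unchanged in all three measured compounds. There is therefore no direct guide for this change, and the size of the step in this assay is uncertain. The two measured steps show that one part of compound 1 tolerates change and another does not, so either outcome is possible.

Compound 4 is expected to give 40 nM in this assay, with a range from 8 nM to 250 nM, which means an expected step of a 5.0-fold higher number from compound 1 to compound 4 (0.70 log units; beyond the scatter), a rise that may still fall within the scatter.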

Compound 4, half-maximal effective concentration: 21800 nM
Beside the measured number, compound 4's estimate is 550-fold (2.74 log units) below it, outside the stated range (above it).
By their numbers in this assay, from the lowest: compounds 1 and 3 (each within the scatter of the next); then compound 2; then compound 4.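

The ring on the saturated chain carbon bound to an amide-type nitrogen turns out to be the most sensitive place seen so far: in this assay, 1H-pyrrol-3-yl in place of thiophen-2-yl gives a 2700-fold higher number from compound 1 to compound 4 (3.44 log units; beyond the scatter), a much larger step than an 8.4-fold higher number from compound 1 to compound 2 (0.92 log units; beyond the scatter) and a 1.3-fold higher number from compound 1 to compound 3 (0.10 log units; within the scatter). Both rings are five-membered and aromatic, with 5 heavy atoms and 1 hetero atom, so keeping these counts is not enough to keep the low number; the counts that do change are sulfur to nitrogen, the hydrogen-bond donor that enters, and the hydrogen-bond acceptor that leaves. No separate measurement here shows why the number rises so far, and the change also moves the point of attachment from position 2 to position 3 of the ring.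

The compounds shown leave open which of these differences accounts for the step, since all of them arrive together in compound 4. A thiophen-3-yl group would test the point of attachment with sulfur kept, while a 1H-pyrrol-2-yl or 1-methylpyrrol-3-yl group would show how far the outcome follows the ring nitrogen and its hydrogen.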